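Acylsulfonamide series: substituent on the aniline ring

The source may hold more compounds than are shown below. What is called first, only, known or untested is meant among the compounds shown, and "the series" means these compounds.

Measured compounds in a functional assay on NCI-H146 cells (Homo sapiens) for cytotoxicity, with a stated time of 48 h, in the presence of a further agent that is not named here; a higher number here means that more compound is needed for the effect, a lower number that less compound is needed:
- compound 1, `CN(C)CC[C@H](CSc1ccccc1)Nc1ccc(S(=O)(=O)NC(=O)c2ccc(N3CCN(Cc4ccccc4-c4ccc(Cl)cc4)CC3)cc2)cc1`: 78700 nM
- compound 2, `CN(C)CC[C@H](CSc1ccccc1)Nc1ccc(S(=O)(=O)NC(=O)c2ccc(N3CCN(CC4=C(c5ccc(Cl)cc5)CCC(C)(C)C4)CC3)cc2)cc1[N+](=O)[O-]`: 98 nM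
- compound 3, `O=C(NS(=O)(=O)c1ccc(NCCSc2ccccc2)c([N+](=O)[O-])c1)c1ccc(N2CCN(Cc3ccccc3-c3ccc(Cl)cc3)CC2)cc1`: 33000 nM

Compound 1 gives the highest number of the three in this assay. Compound 3 sits nearest to it, with a lower number that lies beyond the scatter. Going by the values given here, compound 2 stands furthest away, with a far lower number, but compound 2 differs from compound 1 in more than one place, so no single step between measured compounds is available.

The step to compound 4, `CN(C)CC[C@H](CSc1ccccc1)Nc1ccc(S(=O)(=O)NC(=O)c2ccc(N3CCN(Cc4ccccc4-c4ccc(Cl)cc4)CC3)cc2)cc1C(=O)C(F)(F)F`, is a single change on the core of compound 1:

(trifluoromethyl)carbonyl in place of hydrogen on an aromatic carbon

Both compound 2 and compound 3 carry a group on the aromatic carbon that is unsubstituted in compound 1, and both give lower numbers than compound 1 in this assay, though each also differs from compound 1 elsewhere. On that basis a lower number is expected for compound 4, with a step that goes beyond the scatter, but well short of the gap to compound 2.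

For compound 4 in this assay the estimate is 6000 nM, with a range from 1000 nM to 40000 nM, which as a step means a 13-fold lower number from compound 1 to compound 4 (1.12 log units; beyond the scatter).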

Compound 4, half-maximal effective concentration: 2010 nM
Compound 4: the middle estimate sits 3.0-fold (0.47 log units) above what was measured; the measured number falls inside the stated range.
By their numbers in this assay, from the lowest: compound 2; then compound 4; then compound 3; then compound 1.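

In this assay, (trifluoromethyl)carbonyl in place of hydrogen on the aromatic carbon ortho to a large group and meta to a large group gives a 39-fold lower number from compound 1 to compound 4 (1.59 log units; beyond the scatter) as a large step beyond the scatter. Going by these compounds alone, this is the first reading of this position on its own: compound 2 and compound 3 also carry a group on this carbon, but each differs from compound 1 elsewhere as well, so neither isolates the position, whereas here the rest of the core of compound 1 stays the same and the change in the number belongs to this single replacement. Nothing shown here bears on why the number falls with this group in place.

The compounds shown leave open whether another group on this aromatic carbon, such as a nitrile, an acetyl, an amine or a nitro group on the otherwise unchanged core of compound 1, would give a step of similar size or direction. As far as these compounds go, it also remains open whether the step from this replacement carries over to the other side chains and the other group on the piperazine seen in compound 2 and compound 3.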